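Swapping the aryl group on a thiourea: compound 3 to compound 4

A few compounds are considered here, and "the series" means these few. Any claim that something is new, unique, unknown or untested is made for them only; others in the source may bear on it.

- compound 1 `O=[N+]([O-])c1ccc(NC(=S)Nc2cccc(C(F)(F)F)c2)cc1` gives 10000 nM
- compound 2 `Fc1ccc(NC(=S)Nc2cccc(C(F)(F)F)c2)cc1Cl` gives 20000 nM
- compound 3 `Fc1ccc(NC(=S)Nc2cccc(C(F)(F)F)c2)cc1` gives 40000 nM

In an ADME assay on Vero 76 cells (Chlorocebus sabaeus) for cytotoxicity, read by crystal violet staining, with a stated time of 96 h (on this read-out lower numbers stand for higher toxicity in this test and higher numbers for lower toxicity in this test), compound 3 sits at the upper end of this small set, level with compound 2 and clear of compound 1. Compound 4 `FC(F)(F)c1cccc(NC(=S)Nc2ccccc2Br)c1` is still unmeasured and carries 2-bromophenyl in place of 4-fluorophenyl on an amide-type nitrogen. Going by the values given here, no measured compound carries a bromo group. Two measured steps change this same aryl group. Taking the step of a 2.0-fold higher number from compound 2 to compound 3 (0.30 log units; within the scatter) and the modest step of a 4.0-fold higher number from compound 1 to compound 3 (0.60 log units; beyond the scatter) as the guide, a shift to a lower number is expected in this assay but probably none beyond the scatter. Compound 4 is estimated at 25000 nM with a range of 10000 nM to 60000 nM as the likely span. This estimate means a 1.6-fold lower number from compound 3 to compound 4 (0.20 log units; within the scatter) as the expected step.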

Compound 4, half-maximal cytotoxic concentration: 50000 nM
Estimate against measurement, compound 4: 2.0-fold (0.30 log units) below, and the stated range covers the measured number.
By their numbers in this assay, from the lowest: compounds 1, 2, 3 and 4 (each within the scatter of the next, the first and the last beyond it).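

In this assay the change to 2-bromophenyl on the amide-type nitrogen gives a 1.3-fold higher number from compound 3 to compound 4 (0.10 log units; within the scatter) and brings the first bromo group into the set without a step beyond the scatter. The halogen and its place on the ring change together, so this step cannot separate the two. Going by these compounds alone, the nitro group of compound 1 therefore remains the only change here with a step beyond the scatter, a 4.0-fold higher number from compound 1 to compound 3 (0.60 log units; beyond the scatter).

Nothing available explains the result. Still open, going by these compounds, is whether 4-bromophenyl, or an amine or carboxylic acid on this ring, would stay within the scatter of compound 3.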